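From tert-Butyl to 2-Hydroxyethyl: an Expected Weak Inhibitor

The source may hold more compounds than are shown below. What is called first, only, known or untested is meant among the compounds shown, and "the series" means these compounds.

Compound 1 `O=C1O[C@H]([C@@H](O)Cn2cc(-c3cc(C(F)(F)F)cc(C(F)(F)F)c3)nn2)C(OCc2ccccc2)=C1OCc1ccccc1`: in a functional assay on CFPAC-1 cells (Homo sapiens) for antiproliferative activity, read by MTT assay, with a stated time of 72 h (a lower number here means a stronger inhibitor, a higher number a weaker inhibitor), compound 1 gives 66500 nM.
Compound 2 `CC(C)(C)OC(=O)N1CCN(C(=S)SCc2cn(C[C@H](O)[C@H]3OC(=O)C(OCc4ccccc4)=C3OCc3ccccc3)nn2)CC1`: in this assay compound 2 reaches only a limit of the assay, > 100000 nM, and not a number.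
Compound 3 `CC(C)(C)c1cn(C[C@H](O)[C@H]2OC(=O)C(OCc3ccccc3)=C2OCc2ccccc2)nn1`: in this assay compound 3 gives 54900 nM.

Among the numbers shown, compound 3 carries the lowest one, yet the nearest value, that of compound 1, sits within the usual scatter of repeated measurements, so the two cannot be told apart. One of the three results is a limit rather than a number (the limit of > 100000 nM in this assay, at which 1 of the 3 values shown sits). Among the compounds with values here, no two of the measured compounds differ in a single place, so no measured step is available to lean on.

Compound 4 `O=C1O[C@H]([C@@H](O)Cn2cc(CCO)nn2)C(OCc2ccccc2)=C1OCc1ccccc1` differs from compound 3 in one place: 2-hydroxyethyl in place of tert-butyl on an aromatic carbon. The measured compounds say nothing about how this change acts. With compound 1 and compound 3 so close to each other, and the third result only a limit, the expectation is a step from compound 3 to compound 4 that stays within the scatter, a 1.2-fold higher number from compound 3 to compound 4 (0.07 log units; within the scatter). Compound 4 is therefore estimated to give 65000 nM in this assay, with a range from 25000 nM to 160000 nM, and a fair chance that only a limit is reported.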

Compound 4, half-maximal inhibitory concentration: > 100000 nM
Compound 4 was reported as a limit; the forecaster's own chance of this, stated with the estimate: 30%; middle value at least 1.5-fold (0.18 log units) away from the limit.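

In this assay, within the data shown here, 2-hydroxyethyl in place of tert-butyl on an aromatic carbon gives an at least 1.8-fold higher number from compound 3 to compound 4 (0.26 log units; that floor lies within the scatter), the first step at this position that can be read at all. Compound 4 has only a limit, > 100000 nM, and not a number, so the step has a floor but no fixed size; that floor lies within the scatter, so a real loss cannot be claimed, but the change brings no sign of a gain. The change also moves this position from a measurable number to the top of the assay's range, and results of that kind now make up a larger share of the set: the limit of > 100000 nM in this assay, at which 2 of the 4 values shown sit.

The compounds shown leave open how far above the limit compound 4 truly lies, and whether the outcome follows from the arrival of the hydroxyl or from the departure of tert-butyl. A simple ethyl group, an amine or a carboxylic acid in place of the hydroxyl, or a longer chain bearing it, would separate these two readings at the same aromatic carbon.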